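Adding a second chloro to the core of compound 1

This account rests on a few compounds, and the source may have more. Where it says the series, first, only, none or still open, it means among the compounds named here.

Compound 1, `ClCc1ccccc1Cn1cnc2ncnc(Cl)c21`: 8700 nM
Compound 2, `ClCc1ccc(Cn2cnc3c(Cl)nc(Cl)nc32)cc1`: 38000 nM
Compound 3, `ClCc1cccc(Cn2cnc3nc(Cl)nc(Cl)c32)c1`: 21400 nM

Of the compounds shown here, three have been measured in a functional assay on OVCAR-8 cells (Homo sapiens) for cytotoxicity, read by sulforhodamine B assay, with a stated time of 48 h; on this read-out lower numbers stand for stronger inhibition of growth and higher numbers for weaker inhibition of growth. Compound 1 gives the lowest of the three numbers. Compound 3 lies nearest to it with a number that is higher, beyond the scatter, and compound 2 lies furthest with a number higher still. For the measured compounds named here, compound 2 and compound 3 each differ from compound 1 in more than one place, so no single step among the measured compounds can be read from these values.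

Compound 4, `ClCc1ccccc1Cn1cnc2nc(Cl)nc(Cl)c21`, has not yet been measured. It differs from compound 1 in one place: chloro in place of hydrogen on an aromatic carbon. Going by the values given here, no pair of measured compounds shows this change on its own, so its effect must be estimated rather than read. Compound 2 and compound 3 both carry this extra chloro and both give higher numbers than compound 1, but the change of position on the benzyl group in each case leaves the contribution of the chloro unresolved.

For compound 4 the step of a 1.4-fold higher number from compound 1 to compound 4 (0.14 log units; within the scatter) is expected to be small, and not clearly beyond the scatter in either direction. Compound 4 is therefore estimated at 12000 nM, with a range of 4000 nM to 35000 nM.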

Compound 4, concentration for total growth inhibition: 7070 nM
Beside the measured number, compound 4's estimate is 1.7-fold (0.23 log units) above it; low and high end bracket the measured number.
By their numbers in this assay, from the lowest: compounds 4 and 1 (each within the scatter of the next); then compounds 3 and 2 (each within the scatter of the next).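

In this assay, for the compounds shown here, the step of a 1.2-fold lower number from compound 1 to compound 4 (0.09 log units; within the scatter) gives the first reading of chloro in place of hydrogen on its own, at the aromatic carbon between two ring nitrogen atoms of the core. The change stays within the usual scatter, so this position accepts the added chloro without a shift that can be told apart from repeat measurement, and the contribution of the chloro is now separated from any change on the benzyl group. Nothing measured here offers a reason for this result at this position.

The compounds shown cover only hydrogen and chloro at this carbon, so it remains open whether a larger or different group, such as an amine, a methoxy group or a longer chain, would be accepted there as well. Going by these compounds, it also remains open whether the same chloro would give a similar step if the chloromethyl group on the benzyl ring were replaced, for instance by a hydroxymethyl group.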